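Methoxy on the Phenyl Ring of Compound 2

The source may hold more compounds than are shown below. What is called first, only, known or untested is meant among the compounds shown, and "the series" means these compounds.

Three compounds share one core. Compound 1 `CCOC(=O)C1=C(C)N(c2ccccc2)C=CC1c1ccccc1` gives -34% in a functional assay, tested at 200 ug/mL; a higher number here means a weaker effect of the compound at the concentration tested, a lower number a stronger effect. Compound 2 `COC(=O)C1=C(C)N(c2ccccc2)C=CC1c1ccccc1` gives -43% in this assay, and compound 3 `COC(=O)C1=C(C)N(c2ccccc2)C=C(C)C1c1ccccc1` gives -48%. Compound 2 stands second highest of these three numbers; its nearest neighbour is compound 3 and its furthest is compound 1, and a number 9 percentage points lower from compound 1 to compound 2 (within the scatter) as well as a number 5 percentage points lower from compound 2 to compound 3 (within the scatter) both stay within the scatter. The change to compound 4 `COC(=O)C1=C(C)N(c2ccccc2)C=CC1c1ccc(OC)cc1` is methoxy in place of hydrogen on an aromatic carbon. Neither measured step touches the phenyl ring, so neither bears directly on this change, and both stayed within the scatter, so the step of no change at the digits printed from compound 2 to compound 4 (within the scatter) is expected to show nothing beyond the scatter. Compound 4 is estimated at -43%, between -60% and -25%.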

Compound 4, a percentage reported as activity, at one concentration (the size of the read-out at that concentration, not a potency): -44.8%
Compound 4: the middle estimate sits 1.8 percentage points above what was measured; the measured number falls inside the stated range.
By their numbers in this assay, from the lowest: compounds 3, 4, 2 and 1 (each within the scatter of the next, the first and the last beyond it).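

This is the first step shown that touches the phenyl ring: in this assay, going from phenyl to 4-methoxyphenyl gives a number 1.8 percentage points lower from compound 2 to compound 4 (within the scatter) and so shows no difference that can be told from the scatter. At this carbon, para to a large group, methoxy therefore leaves the read-out where hydrogen had it. Nothing measured here offers an explanation for this result. Still open, as far as these compounds go, is whether a different group at this carbon, such as an amine or a carboxylic acid, would read the same, and whether methoxy would on another carbon of this ring.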